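Dropping both chlorines from the anilide end of compound 1

This account rests on a few compounds, and the source may have more. Where it says the series, first, only, none or still open, it means among the compounds named here.

Measured so far:
compound 1, `O=C(/C=C/C(=O)N1C/C(=C\c2ccccc2)C(=O)/C(=C/c2ccccc2)C1)Nc1ccc(Cl)c(Cl)c1`, 7500 nM
compound 2, `O=C(/C=C/C(=O)N1C/C(=C\c2ccc([N+](=O)[O-])cc2)C(=O)/C(=C/c2ccc([N+](=O)[O-])cc2)C1)Nc1ccc(Cl)cc1`, 3600 nM

Compound 1 is the weaker of the two measured compounds in a functional assay on L1210 cells (Mus musculus) for cytotoxicity; a lower number here means a stronger inhibitor, a higher number a weaker inhibitor: compound 2 gives a lower number, and the gap between them lies beyond the usual scatter. The two compounds differ in more than one place, so their values are simply reported side by side.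

Compound 3, `O=C(/C=C/C(=O)N1C/C(=C\c2ccccc2)C(=O)/C(=C/c2ccccc2)C1)Nc1ccccc1`, has not been measured. It differs from compound 1 in one place: phenyl in place of 3,4-dichlorophenyl on an amide-type nitrogen. For the measured compounds named here, no measured pair shows this change on its own, so nothing here tells its size. The expectation is a small step, at most around the edge of the scatter, toward a higher number, written as a 1.3-fold higher number from compound 1 to compound 3 (0.12 log units; within the scatter). Compound 3 is therefore estimated at 10000 nM in this assay, with a range from 3000 nM to 30000 nM.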

Compound 3, half-maximal inhibitory concentration: 3600 nM
Estimate against measurement, compound 3: 2.8-fold (0.44 log units) above, and the stated range covers the measured number.
By their numbers in this assay, from the lowest: compounds 2 and 3 (each within the scatter of the next); then compound 1.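

The anilide end of the molecule turns out not to depend on its two chlorines: in this assay, replacing 3,4-dichlorophenyl with phenyl on the amide-type nitrogen gives a 2.1-fold lower number from compound 1 to compound 3 (0.32 log units; beyond the scatter). For the compounds shown here, this is a modest step, but it is the only comparison here in which this position changes alone, and it shows that the position affects cytotoxicity and that the unsubstituted phenyl ring gives the stronger compound of this pair. Nothing shown here explains why removing the chlorines moves the number in this direction.

Going by these compounds, whether the two chlorines contribute equally remains open, since a phenyl carrying a single chlorine has no one-place comparison with compound 3 here. Also open, on these data alone, is how other groups on this ring, such as a methoxy group, an amine or a carboxylic acid, would compare with compound 3.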